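Piperazine aryl swap in an oxazole T-type channel series

The compounds below may be only part of what the source reports. "The series", "measured", "known", "first", "only" and "open" are said of these compounds alone.

Compound 1 `CCCc1nc(-c2ccccc2)c(CNCCCN2CCN(c3cccc(F)c3)CC2)o1` is the reference; in an assay on HEK293 cells for inhibition of Voltage-dependent T-type calcium channel subunit alpha-1G (Homo sapiens), read by fluorescence, tested at 10 uM (a lower number here means less inhibition, a higher number more inhibition at the concentration tested (going by the name of the read-out)), compound 1 gives 68.9%. Compound 2 `CCCc1nc(-c2ccccc2)c(CNCCCN2CCN(c3cccc(C)c3C)CC2)o1` differs from it in one place: 2,3-dimethylphenyl in place of 3-fluorophenyl on an amine nitrogen in a ring. That change gave a number 13.7 percentage points lower from compound 1 to compound 2 (beyond the scatter), so in this assay compound 2 gives 55.2%.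

Compound 3 `CCCc1nc(-c2ccccc2)c(CNCCN2CCN(c3cccc(F)c3)CC2)o1` carries a shorter link between the two amine nitrogens; how its core differs from that of compound 1 is not broken down here. In this assay compound 3 gives 62.3%, a number that sits within the usual scatter of the value of compound 1 and of the value of compound 2, so no ordering among these three is claimed.

Compound 4 `CCCc1nc(-c2ccccc2)c(CNCCN2CCN(c3cccc(C)c3C)CC2)o1` has not been measured. It stands to compound 3 exactly as compound 2 stands to compound 1: 2,3-dimethylphenyl in place of 3-fluorophenyl on an amine nitrogen in a ring. Both place lines read the same, so this is the same change on the core of compound 3. Within the data shown here, only one example of the step is known, from compound 1 to compound 2, which limits confidence.

Among the measured compounds shown here, because the single earlier example gave a number 13.7 percentage points lower from compound 1 to compound 2 (beyond the scatter), a step of about the same size is expected here, a number 13.3 percentage points lower from compound 3 to compound 4 (beyond the scatter). In this assay compound 4 is therefore estimated at 49%, expected to fall between 35% and 62%.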

Compound 4, a percentage reported as inhibition, at one concentration (the size of the read-out at that concentration, not a potency): 66.7%
Beside the measured number, compound 4's estimate is 17.7 percentage points below it; measured number above the stated range.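

In this assay, 2,3-dimethylphenyl in place of 3-fluorophenyl on the core of compound 3 gave a number 4.4 percentage points higher from compound 3 to compound 4 (within the scatter), so the step seen on the core of compound 1 did not recur. The size of this change therefore does not carry over between these two cores, and the two steps differ: the same change on two cores in this assay, a number 13.7 percentage points lower (beyond the scatter) from compound 1 to compound 2 and a number 4.4 percentage points higher (within the scatter) from compound 3 to compound 4, 18.1 percentage points apart, beyond the scatter of two such steps This shows that a step measured on one of these cores is a poor guide to the other, but it rests on a single pair of cores and a single pair of aryl groups, and it does not show what produces the difference or establish a general rule for the link between the two amine nitrogens.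

Still open, as far as these compounds go, is how a longer chain between the two amine nitrogens would respond to the same change. From the compounds shown here alone, it is also open whether a pyridyl group or an unsubstituted phenyl on the ring amine nitrogen would show a similar difference between cores.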